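Thiophene cores in the antiproliferative series: chloro for methoxy

This account rests on a few compounds, and the source may have more. Where it says the series, first, only, none or still open, it means among the compounds named here.

Compound 1 `COc1ccc(-c2nsc3c2NC(=O)CC3c2cccc(OC)c2)cc1` gives 591 nM in a functional assay on MDA-MB-435 cells (Homo sapiens) for antiproliferative activity, read by CellTiter-Glo, with a stated time of 96 h; on this read-out lower numbers stand for stronger inhibition and higher numbers for weaker inhibition. Compound 2 `COc1ccc(-c2nsc3c2NC(=O)CC3c2cccc(Cl)c2)cc1` carries the change chloro in place of methoxy on an aromatic carbon and gives 792 nM; the step of a 1.3-fold higher number from compound 1 to compound 2 (0.13 log units; within the scatter). Compound 3 `COc1ccc(-c2nsc3c2NC(=O)CC3c2ccsc2)cc1` differs from compound 1 by thiophen-3-yl in place of 3-methoxyphenyl on a saturated ring carbon. In this assay compound 3 gives 80.7 nM. The step of a 7.3-fold lower number from compound 1 to compound 3 (0.86 log units; beyond the scatter), and against compound 2 the step of a 9.8-fold lower number from compound 2 to compound 3 (0.99 log units; beyond the scatter).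

Compound 4 `O=C1CC(c2ccsc2)c2snc(-c3ccc(Cl)cc3)c2N1` repeats on the core of compound 3 the same kind of change, (chloro in place of methoxy on an aromatic carbon). The place differs: in compound 2 the chloro sits meta to a large group, in compound 4 para to a large group. Because the earlier step of a 1.3-fold higher number from compound 1 to compound 2 (0.13 log units; within the scatter) stayed within the scatter, a step of similar small size is expected, a 1.2-fold higher number from compound 3 to compound 4 (0.09 log units; within the scatter). The estimate for compound 4 in this assay is 100 nM, between 50 nM and 220 nM.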

Compound 4, half-maximal inhibitory concentration: 628 nM
Estimate against measurement, compound 4: 6.3-fold (0.80 log units) below; the measured number lies above the stated range.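

In this assay, chloro in place of methoxy does not carry over as a fixed step from one core to another: the new result is a 7.8-fold higher number from compound 3 to compound 4 (0.89 log units; beyond the scatter). The two steps on the two cores differ: the same change on two cores in this assay, a 1.3-fold higher number (0.13 log units; within the scatter) from compound 1 to compound 2 and a 7.8-fold higher number (0.89 log units; beyond the scatter) from compound 3 to compound 4, 5.8-fold (0.76 log units) apart, beyond the scatter of two such steps. This shows that the step from the earlier pair cannot be transferred to compound 4, but it does not separate the effect of the core from that of the place, since the two pairs differ in both, and it gives no cause.

Open, as far as these compounds go, is what chloro para to a large group does on a core bearing 3-methoxyphenyl. Also open, from the compounds shown here alone, is whether fluoro or an amine in that place stays nearer to compound 3 than chloro does.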